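Compound 1 to compound 4: adding naphthalen-1-yl

A few compounds are considered here, and "the series" means these few. Any claim that something is new, unique, unknown or untested is made for them only; others in the source may bear on it.

In an ADME assay on HEK-293T cells (Homo sapiens) for inhibition, read by CCK-8 assay, with a stated time of 48 h, tested at 20 uM (a higher number here means more inhibition of growth at the concentration tested, a lower number less inhibition of growth), compound 1 (`Cc1ccc(S(=O)(=O)Oc2ccccc2/C=C(\C#N)C(=O)Nc2nnc(C)s2)cc1`) gives 35% as its reading. Compound 3 (`COc1ccc(Cc2nnc(NC(=O)/C(C#N)=C/c3ccccc3OS(=O)(=O)c3ccc(OC)cc3)s2)cc1`) gives 30% as its reading, within the scatter of compound 1. Compound 2 (`CC(=O)Nc1ccc(S(=O)(=O)Oc2cccc(/C=C(\C#N)C(=O)Nc3nnc(-c4cccs4)s3)c2)cc1`) gives 20% as its reading, beyond the scatter below compound 1. Compound 4 (`Cc1ccc(S(=O)(=O)Oc2ccccc2/C=C(\C#N)C(=O)Nc2nnc(Cc3cccc4ccccc34)s2)cc1`) carries naphthalen-1-yl in place of hydrogen on a saturated chain carbon bound to an aromatic carbon, turning methyl into (naphthalen-1-yl)methyl. No measured pair sizes this change directly. Compound 3, with its large substituent, still reads 30% in this series, so little movement is expected in this assay and nothing beyond the scatter. The expected a number 5 percentage points lower from compound 1 to compound 4 (within the scatter) is slight and downward. Compound 4 is estimated at 30% within an expected range of 15% to 50% for this measurement.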

Compound 4, percent growth inhibition at one concentration: 23%
For compound 4 the middle estimate is 7 percentage points above the measured one; the measured number falls inside the stated range.
By their numbers in this assay, from the lowest: compounds 2, 4, 3 and 1 (each within the scatter of the next, the first and the last beyond it).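

In this assay, within the data shown here, naphthalen-1-yl in place of hydrogen on a saturated chain carbon bound to an aromatic carbon gives a number 12 percentage points lower from compound 1 to compound 4 (beyond the scatter) as the first single-place step. This position therefore responds to the change, modestly but beyond the scatter, which compounds 1, 2 and 3 could not show because they differ in more than one place. No measurement shown gives a reason for this step.

As far as these compounds go, whether phenyl or an amine on the same carbon would move the reading as far remains open. So does whether naphthalen-1-yl has the same effect on the core of compound 2.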